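Compound 4: a 3,3-dimethyloxiran-2-yl group on the chain

The source may hold more compounds than are shown below. What is called first, only, known or untested is meant among the compounds shown, and "the series" means these compounds.

In a functional assay on A549 cells (Homo sapiens) for cytotoxicity, read by MTT assay, with a stated time of 48 h (a lower number here means a stronger inhibitor, a higher number a weaker inhibitor), compound 3 `C=CC(C)(O)CC[C@@H]1C(=C)CC[C@H](Br)[C@@]1(C)CCC(OC)C(C)(C)O` gives only a limit, > 100000 nM. Compound 1 `C=CC(C)(O)CC[C@@H]1C(=C)CC[C@H](Br)[C@@]1(C)CCC(O)C(C)(C)Cl` gives 94100 nM. Compound 2 `C=CC(C)(O)CC[C@@H]1C(=C)CC[C@H](Br)[C@@]1(C)CCC(Br)C(C)(C)O` gives > 100000 nM; 86900 nM (2 entries). Within the data shown here, the single measured step, an at least 1.0-fold higher number from compound 1 to compound 3 (0.02 log units; that floor lies within the scatter), lies within the scatter. Compound 4 `C=CC(C)(O)CC[C@@H]1C(=C)CC[C@H](Br)[C@@]1(C)CCC1OC1(C)C` carries 3,3-dimethyloxiran-2-yl in place of 2-hydroxy-1-methoxy-2-methylpropyl on a saturated chain carbon, two bonds along the chain from a saturated ring carbon. Among the measured compounds shown here, no measured step makes this exact exchange, so the only guide is that small step and the similar readings of compound 2, (the several entries of compound 2 in this assay, > 100000 nM; 86900 nM (2 entries)). A step no larger than the scatter is therefore expected, an at least 1.1-fold lower number from compound 3 to compound 4 (0.07 log units; that floor lies within the scatter). For compound 4 the estimated value is 85000 nM, with an expected range from 40000 nM to 150000 nM.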

Compound 4, half-maximal inhibitory concentration: > 100000 nM
Compound 4 gave a limit, no number; the forecaster's own chance of this, stated with the estimate: 45%; middle value at least 1.1-fold (0.07 log units) from the limit.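

In this assay compound 4, with the three-membered 3,3-dimethyloxiran-2-yl ring on the chain, gives > 100000 nM, which is a limit of the assay. Against the open-chain group of compound 1, the only readable comparison is an at least 1.0-fold higher number from compound 1 to compound 4 (0.02 log units; that floor lies within the scatter), while the step between compound 3 and compound 4 cannot be read. A ring at this position therefore gives no reading that separates it from the open-chain groups, and the values gather at one ceiling: the limit of > 100000 nM in this assay, at which 2 of the 4 values shown sit. Going by these compounds, it remains open whether any group here could give a clearly lower number, for example an amine or a carboxylic acid in place of 3,3-dimethyloxiran-2-yl.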